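The source may hold more compounds than are shown below. What is called first, only, known or untested is meant among the compounds shown, and "the series" means these compounds.

Measured so far:
compound 1, `COc1cc(OC)c(OC)cc1/C=C/COC(=O)/C=C/c1cc(OC)c(OC)c(OC)c1OC`: 50%
compound 2, `COc1cc(OC)c(OC)cc1/C=C/COC(=O)/C=C/c1ccccc1C(F)(F)F`: 75%

In a functional assay on the whole organism (strain Kunming) with Mus musculus as the target, with a stated time of 0.5 h, at a dose of 300 mg/kg by the intraperitoneal route (on this read-out higher numbers stand for a weaker effect at the one dose given and lower numbers for a stronger effect), compound 2 gives 75%, the highest of the two numbers; its nearest neighbour, compound 1, gives 50%, a gap beyond the scatter. Compound 3, `COc1ccc(/C=C/C(=O)OC/C=C/c2cc(OC)c(OC)cc2OC)cc1`, is not yet measured. It differs from compound 2 in one place: 4-methoxyphenyl in place of 2-(trifluoromethyl)phenyl on a double-bonded chain carbon bound to a double-bonded chain carbon. Among the measured compounds shown here, no step between two measured compounds tracks this change. Compound 3 is expected to move toward compound 1, which gives 50%, since both carry methoxy groups. The expected step for compound 3 is a number 13 percentage points lower from compound 2 to compound 3 (beyond the scatter), a moderate one. Compound 3 is estimated at 62%, between 45% and 80%.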

Compound 3, a percentage reported as activity, at one dose (the size of the read-out at that dose, not a potency): 100%
Estimate against measurement, compound 3: 38 percentage points below; measured number outside the range, above it.
By their numbers in this assay, from the lowest: compound 1; then compound 2; then compound 3.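

Under this assay, 4-methoxyphenyl in place of 2-(trifluoromethyl)phenyl gives a number 25 percentage points higher from compound 2 to compound 3 (beyond the scatter) and so a weaker effect at the one dose given. This position on a double-bonded chain carbon bound to a double-bonded chain carbon therefore responds to the group it carries, and methoxy here does not bring a stronger effect. Nothing at hand accounts for the step.

This single pair cannot separate losing trifluoromethyl from gaining methoxy. From the compounds shown here alone, how an unsubstituted phenyl or a carboxylic acid at this place would read remains open.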